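This account rests on a few compounds, and the source may have more. Where it says the series, first, only, none or still open, it means among the compounds named here.

Compound 2 `O=C(Nc1ccnnc1)c1cc(N2CCNCC2)ccc1OCc1ccccc1` gives 15.9 nM in an assay on Sf9 cells for inhibition of Leucine-rich repeat serine/threonine-protein kinase 2 (Homo sapiens), read by TR-FRET, with stated times of 30 min and 2 h; a lower number here means a stronger inhibitor, a higher number a weaker inhibitor. For the measured compounds named here, of the two numbers known, that of compound 2 is the lower, although its gap to compound 1 `CN1CCC(c2ccc(OCc3ccccc3)c(C(=O)Nc3ccnnc3)c2)CC1`, which gives 20 nM in this assay, lies within the scatter. Going by the values given here, the only step that bears on the same position is a 1.3-fold lower number from compound 1 to compound 2 (0.10 log units; within the scatter), where exchanging one ring-bound amine group for another barely moved the number. Compound 3 `CN1CC2(C1)CN(c1ccc(OCc3ccccc3)c(C(=O)Nc3ccnnc3)c1)C2` carries a group of 8 heavy atoms (6 carbon, 2 nitrogen; 2 four-membered non-aromatic rings with 1 hetero atom each) in place of a group of 6 heavy atoms (4 carbon, 2 nitrogen; one six-membered non-aromatic ring with 2 hetero atoms), on an aromatic carbon. On that basis no shift beyond the scatter is expected, and compound 3 is estimated at 20 nM, with a range from 7 nM to 60 nM, which would mean an expected step of a 1.3-fold higher number from compound 2 to compound 3 (0.10 log units; within the scatter).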

Compound 3, half-maximal inhibitory concentration in the Leucine-rich repeat serine/threonine-protein kinase 2 assay: 25.1 nM
For compound 3 the middle estimate is 1.3-fold (0.10 log units) below the measured one; low and high end bracket the measured number.
By their numbers in the Leucine-rich repeat serine/threonine-protein kinase 2 assay, from the lowest: compounds 2, 1 and 3 (each within the scatter of the next).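

On this aromatic carbon, a group with two four-membered rings is tolerated as well as the six-membered rings in the Leucine-rich repeat serine/threonine-protein kinase 2 assay, with a 1.6-fold higher number from compound 2 to compound 3 (0.20 log units; within the scatter) and a 1.3-fold higher number from compound 1 to compound 3 (0.10 log units; within the scatter). For the compounds shown here, what the earlier compounds could not show is that such a change can leave that number within the scatter yet still register in a physicochemical assay for solubility, measured as kinetic solubility (a higher number here means a more soluble compound, a lower number a less soluble compound), modestly but beyond the scatter: the measured solubility of compound 2, 98000 nM, and of compound 3, 198000 nM, a 2.0-fold higher number (0.31 log units; beyond the scatter) In the physicochemical assay compound 2 gives 98000 nM and compound 3 gives 198000 nM.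

The compounds shown do not separate the effect of ring shape from that of losing the hydrogen-bond donor of piperazin-1-yl. Going by these compounds, whether a morpholine or an open-chain dimethylamino group here would behave alike in the Leucine-rich repeat serine/threonine-protein kinase 2 assay and the physicochemical assay remains open.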